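The source may report more compounds than this note shows. Statements on the series, on what has been measured and on what is new or still open speak of the compounds shown alone.

In a functional assay on M4E cells (Homo sapiens) for cytotoxicity, read by resazurin assay, with a stated time of 72 h (on this read-out lower numbers stand for stronger inhibition and higher numbers for weaker inhibition), compound 1 `COc1cc(/C=C/C(=O)OCCCCCCO[N+](=O)[O-])ccc1O` gives > 50000 nM, which is a limit of the assay. For the measured compounds named here, compound 2 `COc1cc(/C=C/C(=O)OCCCCCO[N+](=O)[O-])ccc1O` gives 21800 nM, the only full number so far. Compound 3 `COc1cc(/C=C/C(=O)OCCCO[N+](=O)[O-])ccc1O` differs from compound 2 by nitrooxy in place of 2-(nitrooxy)ethyl on a saturated chain carbon, three bonds along the chain from an oxygen next to a carbonyl group: nitrooxy in place of 2-(nitrooxy)ethyl on a saturated chain carbon. Going by the values given here, the one measured step bearing on this is a shorter change of the same chain, an at least 2.2-fold lower number from compound 1 to compound 2 (0.36 log units; beyond the scatter), and it starts from a limit, so its true size is open. A modest further move to a lower number in this assay is expected, estimated as a 1.8-fold lower number from compound 2 to compound 3 (0.26 log units; within the scatter). Compound 3 is expected at 12000 nM, within 4000 nM to 40000 nM.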

Compound 3, half-maximal inhibitory concentration: 18400 nM
Compound 3: the middle estimate sits 1.5-fold (0.19 log units) below what was measured, within the range that was stated.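

In this assay, the change from 2-(nitrooxy)ethyl to nitrooxy at this place stays within the scatter (a 1.2-fold lower number from compound 2 to compound 3 (0.07 log units; within the scatter)), so the move seen from compound 1 to compound 2 does not carry on as a further step here. The change from 3-(nitrooxy)propyl to nitrooxy lies beyond the scatter (an at least 2.7-fold lower number from compound 1 to compound 3 (0.43 log units; beyond the scatter)). Compound 1 stands at a limit, so the true size of that step stays open: the limit of > 50000 nM in this assay, at which 1 of the 3 values shown sits.

From the compounds shown here alone, whether a chain ending in a hydroxyl group or a carboxylic acid in place of the nitrooxy group would shift the number remains open.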